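The source may hold more compounds than are shown below. What is called first, only, known or untested is meant among the compounds shown, and "the series" means these compounds.

In a functional assay on HCT-116 cells (Homo sapiens) for antiproliferative activity, read by CCK-8 assay, with a stated time of 72 h (a lower number here means a stronger inhibitor, a higher number a weaker inhibitor), compound 1 (`CCc1ccc(SCc2ccc(C(=O)Nc3ccccc3N)cc2)cc1`) gives 1740 nM and compound 2 (`Nc1ccccc1NC(=O)c1ccc(CSCCc2ccccc2)cc1`) gives 2810 nM. Going by the values given here, these are the only two measurements so far, and they cannot be ranked, since the gap between them is no larger than the usual variation between repeat measurements. Compound 2 therefore stands level with compound 1, at low micromolar concentrations.

The next compound, compound 3 (`Nc1ccccc1NC(=O)c1ccc(CSc2ccc(Cl)cc2)cc1`), keeps the shared core but changes the group on the sulfur: 4-chlorophenyl in place of phenethyl, (4-chlorophenyl in place of phenethyl on a sulfur).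

Among the compounds with values here, only one measured step bears on this change, because it acts at the same place: a 1.6-fold higher number from compound 1 to compound 2 (0.21 log units; within the scatter). That step swapped 4-ethylphenyl for phenethyl on the sulfur and stayed within the scatter. Within the data shown here, compound 3 carries a 4-chlorophenyl there, much as compound 1 carries a 4-ethylphenyl, but no measured compound yet shows the effect of the chlorine itself.

No step beyond the scatter is therefore expected in this assay. The expected change is a 1.5-fold lower number from compound 2 to compound 3 (0.17 log units; within the scatter). Compound 3 is estimated at about 1900 nM, with an expected range of 750 nM to 4800 nM.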

Compound 3, half-maximal inhibitory concentration: 3750 nM
For compound 3 the middle estimate is 2.0-fold (0.30 log units) below the measured one; low and high end bracket the measured number.
By their numbers in this assay, from the lowest: compounds 1, 2 and 3 (each within the scatter of the next, the first and the last beyond it).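

In this assay, 4-chlorophenyl in place of phenethyl on the sulfur gives a 1.3-fold higher number from compound 2 to compound 3 (0.13 log units; within the scatter), so these two groups cannot be told apart at this position, although one carries its aromatic ring directly on the sulfur and the other does not. Going by these compounds alone, the new compound also allows the first comparison of two groups on that aromatic ring: chloro in place of ethyl on an aromatic carbon gives a 2.2-fold higher number from compound 1 to compound 3 (0.33 log units; beyond the scatter), a modest step, but the only one so far beyond the scatter, showing that a change on the ring can register in this assay even though the number stays in the low micromolar range. Nothing shown here explains either step.

Whether this small step reflects something particular to chloro and ethyl remains open, as other groups at that ring position, such as methoxy, an amine or a carboxylic acid, are not among the compounds shown. Also open, going by these compounds, is how a longer chain ending in a phenyl ring would compare with phenethyl on the sulfur.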